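Sulfamoylurea amides: swapping the pyridine for a dimethyluracil

The source may report more compounds than this note shows. Statements on the series, on what has been measured and on what is new or still open speak of the compounds shown alone.

Of the compounds shown here, three built on the same sulfamoylurea-piperidine core have been tested in a functional assay on the whole organism (blood) with Rattus norvegicus as the target, with stated times of 24 h and 1 h, at a dose of 15 mg/kg by the intraperitoneal route; on this read-out higher numbers stand for a stronger effect at the one dose given and lower numbers for a weaker effect. Compound 1 `COc1ncccc1C(=O)NCCC1CCN(S(=O)(=O)NC(=O)NC2CCCCC2)CC1` gives 35%, compound 2 `COc1ccc(C(=O)NCCC2CCN(S(=O)(=O)NC(=O)NC[C@@H]3C[C@@H]4C=C[C@@H]3C4)CC2)cn1` gives 32%, and compound 3 `CC#N.O=C(NC[C@@H]1C[C@@H]2CC[C@@H]1O2)NS(=O)(=O)N1CCC(CCNC(=O)c2nc3ccccc3s2)CC1` gives 30%. Compound 2 holds the second highest of the three numbers, yet its gap to compound 1 and its gap to compound 3 both lie within the usual scatter, so the three cannot be told apart on this read-out.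

Compound 4 `Cn1cc(C(=O)NCCC2CCN(S(=O)(=O)NC(=O)NC[C@@H]3C[C@@H]4C=C[C@@H]3C4)CC2)c(=O)n(C)c1=O` has not yet been measured. It differs from compound 2 only at the amide end: a group of 10 heavy atoms (6 carbon, 2 nitrogen, 2 oxygen; one six-membered aromatic ring with 2 hetero atoms) in place of a group of 8 heavy atoms (6 carbon, 1 nitrogen, 1 oxygen; one six-membered aromatic ring with 1 hetero atom), on a carbonyl carbon

Within the data shown here, no pair of measured compounds differs in one place, so no single step is known. Across the three amide caps seen so far the numbers stay close together, and the change on the carbonyl carbon is therefore expected to give a step from compound 2 to compound 4 of no more than the scatter, in either direction: a number 2 percentage points lower from compound 2 to compound 4 (within the scatter). Compound 4 is estimated to give 30% in this assay, within a range from 15% to 45%.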

Compound 4, a percentage reported as activity, at one dose (the size of the read-out at that dose, not a potency): 32%
Compound 4: middle estimate off by 2 percentage points, on the low side; the range from low to high includes it.
By their numbers in this assay, from the lowest: compounds 3, 2, 4 and 1 (each within the scatter of the next).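

Among these compounds, this is the first single-place step: in this assay, replacing the 6-methoxypyridin-3-yl group on a carbonyl carbon with a six-membered aromatic ring with 2 hetero atoms gives no change at the digits printed from compound 2 to compound 4 (within the scatter) on the read-out. At this position, the read-out at the one dose does not separate the two groups, although the entering group has 10 heavy atoms and 4 hydrogen-bond acceptors where the leaving group has 8 heavy atoms and 2 hydrogen-bond acceptors. Nothing measured here bears on why the two groups read alike.

As far as these compounds go, it remains open whether any group on this carbonyl carbon, such as an unsubstituted phenyl ring, a carboxylic acid or an aliphatic amine, would move the number beyond the scatter. From the compounds shown here alone, it also remains open whether the two groups would still read alike at another dose.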